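Series notes: piperidine nitrogen substituent, carbamate to trifluoromethylcyclopentylmethyl

The source may hold more compounds than are shown below. What is called first, only, known or untested is meant among the compounds shown, and "the series" means these compounds.

Compound 1 `CC(C)(C)OC(=O)N1CCC(OC2CCCC(Oc3ccc(S(C)(=O)=O)cc3)C2)CC1` was tested in a functional assay on isolated protein for agonist activity at Glucose-dependent insulinotropic receptor (Homo sapiens), read by HTRF and cAMP accumulation (a lower number here means that less compound is needed, a higher number that more compound is needed for the effect), and reached only the assay limit of > 100000 nM, which is a limit and not a number (the limit of > 100000 nM in this assay, at which 1 of the 3 values shown sits). Compound 2 `CC(C)(C)OC(=O)N1CCC(O[C@H]2CC[C@H](Oc3ccc(S(C)(=O)=O)cc3)CC2)CC1` gives 16.1 nM in this assay. Compound 3 `CS(=O)(=O)c1cnc(O[C@H]2CC[C@H](OC3CCN(C(=O)OC4CCOC4)CC3)CC2)cn1` gives 427 nM in this assay, the highest of the two numbers in the set, and the gap to compound 2 lies beyond the scatter.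

Compound 4 `CS(=O)(=O)c1cnc(O[C@H]2CC[C@H](OC3CCN(CC4(C(F)(F)F)CCCC4)CC3)CC2)cn1` has not been measured. It differs from compound 3 at the piperidine nitrogen: a group of 10 heavy atoms (7 carbon, 3 fluorine; one five-membered non-aromatic ring of carbon only) in place of a group of 8 heavy atoms (5 carbon, 3 oxygen; one five-membered non-aromatic ring with 1 hetero atom), on an amine nitrogen in a ring. Within the data shown here, no measured pair in the set reports this kind of exchange, so the expected step from compound 3 to compound 4 in this assay is estimated as a 1.7-fold lower number from compound 3 to compound 4 (0.23 log units; within the scatter), a modest move toward a lower number that may not exceed the scatter. Compound 4 is therefore expected to give about 250 nM in this assay, within a range from 40 nM to 1500 nM.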

Compound 4, half-maximal effective concentration: 48.8 nM
Estimate against measurement, compound 4: 5.1-fold (0.71 log units) above; measured number inside the range.
By their numbers in this assay, from the lowest: compound 2; then compound 4; then compound 3. At a limit, above all of these: compound 1.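

Among these compounds, at the piperidine nitrogen, on an amine nitrogen in a ring, replacing ((oxolan-3-yl)oxy)carbonyl with the trifluoromethylcyclopentylmethyl group gives an 8.8-fold lower number from compound 3 to compound 4 (0.94 log units; beyond the scatter) in this assay, the first readable step at this position. The carbamate carbonyl is therefore not required for activity in this pair, and an entering group with 0 hydrogen-bond acceptors can replace one with 3 without loss in this assay. Nothing measured here accounts for the size of this step.

From the compounds shown here alone, this single exchange changes both the link to the nitrogen and the ring, so the contribution of each remains open. A plain cyclopentylmethyl group, or a carbamate carrying the trifluoromethylcyclopentylmethyl group, on the core of compound 3 would separate the two.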